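Thiophene in Place of Chlorophenyl on a Thiosemicarbazone

The compounds below may be only part of what the source reports. "The series", "measured", "known", "first", "only" and "open" are said of these compounds alone.

Compound 2 `CC1=CC[C@H](C(C)(C)NC(=S)N/N=C/c2ccccc2Cl)CC1` stands at the edge of what a functional assay on NCI/ADR-RES cells (Homo sapiens) for inhibition, read by sulforhodamine B assay, with a stated time of 48 h (a lower number here means a stronger inhibitor of growth, a higher number a weaker inhibitor of growth), can report. In this assay compound 2 gives > 100000 nM, which is a limit of the assay and not a number (the limit of > 100000 nM in this assay, at which 1 of the 2 values shown sits). Among the compounds with values here, its only measured neighbour, compound 1 `COc1ccc(/C=N/NC(=S)NC(C)(C)[C@H]2CC=C(C)CC2)cc1`, gives 50400 nM in this assay. The step of an at least 1.9-fold higher number from compound 1 to compound 2 (0.29 log units; that floor lies within the scatter) therefore has only a floor, and that floor lies within the scatter. Compound 3 `CC1=CC[C@H](C(C)(C)NC(=S)N/N=C/c2cccs2)CC1` has not yet been measured in this assay; it differs from compound 2 by thiophen-2-yl in place of 2-chlorophenyl on a carbon with a double bond to nitrogen. Within the data shown here, the single measured step that bears on such an aryl exchange is the one from compound 1 to compound 2, and it showed nothing beyond the scatter, so no step beyond the scatter is expected from compound 2 to compound 3 in this assay; the direction remains open, since compound 2 sits at the limit. Compound 3 is estimated to give 90000 nM in this assay, within a range from 25000 nM to 300000 nM, which amounts to an expected step of an at least 1.1-fold lower number from compound 2 to compound 3 (0.04 log units; that floor lies within the scatter).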

Compound 3, concentration for total growth inhibition: 41000 nM
Beside the measured number, compound 3's estimate is 2.2-fold (0.34 log units) above it, within the range that was stated.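

At the carbon with a double bond to nitrogen, an aryl exchange now gives a step that can be read beyond the scatter in this assay, which the earlier pair could not show: an at least 2.4-fold lower number from compound 2 to compound 3 (0.38 log units; beyond the scatter). Compound 2 still rests on a limit of the assay and not on a number, so this step is only a floor and its full size stays unknown: the limit of > 100000 nM in this assay, at which 1 of the 3 values shown sits.

Within the data shown here, the exchange of 4-methoxyphenyl for thiophen-2-yl gives a 1.2-fold lower number from compound 1 to compound 3 (0.09 log units; within the scatter), so these two groups are not told apart here, and among the three compounds only the pair of 2-chlorophenyl and thiophen-2-yl is separated beyond the scatter.

The compounds shown leave open whether the gap belongs to the chlorine or to the 2-chlorophenyl group as a whole, which a plain phenyl group at this carbon would help to decide. They also leave open how a furan-2-yl or pyridin-2-yl group would stand at the same place, and whether a thiophene bearing a methyl group or an amine would keep the value of compound 3.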